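The source may report more compounds than this note shows. Statements on the series, on what has been measured and on what is new or still open speak of the compounds shown alone.

Measured compounds and their values in a functional assay on CHO cells for positive allosteric modulation of muscarinic acetylcholine receptor M5 (Homo sapiens), read by calcium flux; a lower number here means a smaller maximal response, a higher number a larger maximal response:

Compound 1, `CCN(Cc1ccccc1)C(=O)C1CCN(S(=O)(=O)c2ccc3occc3c2)CC1`: 80%
Compound 2, `CCN(Cc1ccccc1)C(=O)C1CCN(S(=O)(=O)c2ccc3cn[nH]c3c2)CC1`: 86%
Compound 3, `CCN(Cc1cccc(F)c1)C(=O)C1CCN(S(=O)(=O)c2ccc3cn[nH]c3c2)CC1`: 89%

Compound 3 gives the last of these three numbers, yet the two steps that lead to it, a number 6 percentage points higher from compound 1 to compound 2 (within the scatter) and a number 3 percentage points higher from compound 2 to compound 3 (within the scatter), are both within the scatter, so the three compounds cannot be told apart in this assay.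

Compound 4, `CCN(Cc1cccc(OC)c1)C(=O)C1CCN(S(=O)(=O)c2ccc3cn[nH]c3c2)CC1`, has not been measured. It differs from compound 3 in one place: methoxy in place of fluoro on an aromatic carbon. Within the data shown here, the only measured step at that same aromatic carbon is a number 3 percentage points higher from compound 2 to compound 3 (within the scatter), where a fluoro entered in place of hydrogen and nothing beyond the scatter followed. Among the measured compounds shown here, no measured step introduces a methoxy anywhere, so the data give no direct guide for this group; the expectation therefore rests on the quiet behaviour of that position so far.

Compound 4 is thus expected to show a number 2 percentage points lower from compound 3 to compound 4 (within the scatter), that is, no step beyond the scatter. For compound 4 in this assay the estimated value is 87%, with a range from 77% to 96%.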

Compound 4, largest response reached (reported as percent of maximum), in percent of the reference or control that the assay uses: 85%
Compound 4: middle estimate off by 2 percentage points, on the high side; measured number inside the range.
By their numbers in this assay, from the lowest: compounds 1, 4, 2 and 3 (each within the scatter of the next).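

In this assay, putting methoxy in place of fluoro on this aromatic carbon gives a number 4 percentage points lower from compound 3 to compound 4 (within the scatter), and setting methoxy against plain hydrogen gives a number 1 percentage points lower from compound 2 to compound 4 (within the scatter). This position has now carried hydrogen, fluoro and methoxy, a group of two heavy atoms with a hydrogen-bond acceptor, and none of these changes moves the maximal response beyond the scatter. No further data here bear on why the response holds steady.

On these data alone, whether an amine, a carboxylic acid or a longer chain such as butoxy on this carbon would shift the response beyond the scatter remains open. So does whether methoxy would behave the same way on another carbon of that ring, or with 1-benzofuran-5-yl in place of 1H-indazol-6-yl on the sulfonyl sulfur.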